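A few compounds are considered here, and "the series" means these few. Any claim that something is new, unique, unknown or untested is made for them only; others in the source may bear on it.

Working notes on the series. Two members of the shared core have been measured in an assay on cells for inhibition of Voltage-dependent T-type calcium channel subunit alpha-1H (Homo sapiens), read by patch clamp, tested at 10 uM; on this read-out higher numbers stand for more inhibition at the one concentration tested (going by the name of the read-out) and lower numbers for less inhibition. Compound 1 `O=C(CC1c2ccccc2N=C(SCCCCCN2CCCC2)N1c1ccccc1)NCc1ccc(F)cc1` gives 40% in this assay; compound 2 `CN(C)CCCCCSC1=Nc2ccccc2C(CC(=O)NCc2ccccc2)N1c1ccccc1` gives 51.8%, the highest of the two numbers, the nearest being compound 1, a gap beyond the scatter. Compound 3 `O=C(CC1c2ccccc2N=C(SCCCCCN2CCCC2)N1c1ccccc1)NCc1ccccc1` has not yet been measured. Compound 3 differs from compound 2 by pyrrolidin-1-yl in place of dimethylamino on a saturated chain carbon, five bonds along the chain from a sulfur. Among the measured compounds shown here, no step between measured compounds is available for this change, so only a small step is expected: a number 6.8 percentage points lower from compound 2 to compound 3 (within the scatter), within or at the edge of the scatter, if anything downward. Compound 3 is therefore estimated at 45%, with a range of 30% to 60% in this assay.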

Compound 3, a percentage reported as inhibition, at one concentration (the size of the read-out at that concentration, not a potency): 61.6%
For compound 3 the middle estimate is 16.6 percentage points below the measured one, outside the stated range (above it).
By their numbers in this assay, from the lowest: compound 1; then compounds 2 and 3 (each within the scatter of the next).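

Pyrrolidin-1-yl in place of dimethylamino on a saturated chain carbon, five bonds along the chain from a sulfur, gives a number 9.8 percentage points higher from compound 2 to compound 3 (within the scatter) in this assay, so this position accepts the ring with no change that stands clear of the scatter. Hydrogen in place of fluoro on an aromatic carbon gives a number 21.6 percentage points higher from compound 1 to compound 3 (beyond the scatter) and is the only new step beyond the scatter. Nothing at hand gives a cause for either step. Still open, as far as these compounds go, is whether piperidin-1-yl or morpholin-4-yl on the chain would fit as pyrrolidin-1-yl does. Also open, from the compounds shown here alone, is whether chloro or methoxy on that aromatic carbon would track fluoro.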